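Replacing the carbamoyl cap: working notes on compound 3

The compounds below may be only part of what the source reports. "The series", "measured", "known", "first", "only" and "open" are said of these compounds alone.

Measured compounds:
compound 1, `CN1CCC(CN(Cc2ccc(Cl)cc2)Cc2ccc([N+](=O)[O-])s2)C1`, "not determined" (no result reported)
compound 2, `O=C(Nc1ccc([N+](=O)[O-])cc1)N1CCC(CN(Cc2ccc(Cl)cc2)Cc2ccc([N+](=O)[O-])s2)C1`, 400 nM
compound 3, `CS(=O)(=O)N1CCC(CN(Cc2ccc(Cl)cc2)Cc2ccc([N+](=O)[O-])s2)C1`, awaiting measurement

In a functional assay on HEK293 cells for agonist activity at nuclear receptor subfamily 1 group D member 1 (Homo sapiens), read by a luciferase reporter, with a stated time of 24 h (a higher number here means that more compound is needed for the effect, a lower number that less compound is needed), compound 2 gives 400 nM. Going by the values given here, this is the only number in the set, since compound 1 carries no result, so compound 2 cannot be placed relative to any other compound on this assay; it is simply the sole reference point.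

Compound 3 is obtained from compound 2 by the change (methylsulfonyl in place of (4-nitrophenyl)carbamoyl on an amine nitrogen in a ring). Among the compounds with values here, no step between two measured compounds is available to calibrate how this position responds to substitution, so the expectation rests on the size of the change alone: a large group is removed and a much smaller one put in its place, and with the reference compound 2 at 400 nM the expected outcome is a step to weaker activity, beyond the usual scatter, though with wide uncertainty in both directions. For compound 3 the estimated step is a 3.8-fold higher number from compound 2 to compound 3 (0.57 log units; beyond the scatter). Compound 3 is therefore expected to give about 1500 nM in this assay, within a range of 400 nM to 6000 nM.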

Compound 3, half-maximal effective concentration: 570 nM
Beside the measured number, compound 3's estimate is 2.6-fold (0.42 log units) above it, and the stated range covers the measured number.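

In this assay the step is a 1.4-fold higher number from compound 2 to compound 3 (0.15 log units; within the scatter), so this pair gives the first calibration of the amine nitrogen in the five-membered ring, and the exchange does not register in this read-out. (4-Nitrophenyl)carbamoyl, with 12 heavy atoms, a six-membered aromatic ring and 1 hydrogen-bond donor, and methylsulfonyl, with 4 heavy atoms, no ring and 0 hydrogen-bond donors, cannot be told apart here, which means that in this pair neither the aromatic ring nor the donor of the carbamoyl group is needed to keep activity at this level. No measurement bears on why two such different groups read alike.

From the compounds shown here alone, whether this nitrogen needs such a cap at all remains open, and a free amine, an acetyl group or a longer chain such as butylsulfonyl on the same nitrogen would address that question. Also open, going by these compounds, is whether the equivalence of these two groups holds beyond the shared core of compound 2 and compound 3, as a single pair cannot establish a trend.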